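The source may report more compounds than this note shows. Statements on the series, on what has been measured and on what is new or still open speak of the compounds shown alone.

Measured so far:
compound 1, `O=C1OC(c2ccc(Cl)cc2)=C/C1=C\c1ccccc1Cl` — in a functional assay on the whole organism (strain Wistar) for inhibition, with Rattus norvegicus as the target, with stated times of 30 min and 2 h, at a dose of 20 mg/kg by the oral route (a higher number here means more inhibition at the dose given (going by the name of the read-out), a lower number less inhibition), compound 1 gives 62.7%
compound 2, `O=C1/C(=C/c2ccccc2)C=C(c2ccc(Cl)cc2)N1Cc1ccccc1` — in this assay compound 2 gives 24%

Compound 2 holds the lower of the two numbers in this assay; the nearer compound, compound 1, stands higher by an amount beyond the scatter, but the two structures differ in more than one place, so that gap is not a single step and carries no cause here.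

Compound 3, `O=C1/C(=C/c2ccc(Cl)cc2)C=C(c2ccc(Cl)cc2)N1Cc1ccccc1`, is not yet measured. It differs from compound 2 by chloro in place of hydrogen on an aromatic carbon, the chloro sitting on an aromatic carbon of a six-membered aromatic ring of carbon only, para to a large group. Within the data shown here, no step between measured compounds isolates this change, so the expectation rests on compound 2 alone: a small step in this assay, if any, more likely upward than downward, and not clearly beyond the scatter. The expected step from compound 2 to compound 3 is a number 9 percentage points higher from compound 2 to compound 3 (within the scatter). Compound 3 is estimated to give 33%, within 12% to 58%.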

Compound 3, a percentage reported as inhibition, in the whole organism at one dose (the size of the read-out at that dose, not a potency): 58.7%
Estimate against measurement, compound 3: 25.7 percentage points below; the whole stated range lies below it.
By their numbers in this assay, from the lowest: compound 2; then compounds 3 and 1 (each within the scatter of the next).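

In this assay, among these compounds, the change from phenyl to 4-chlorophenyl is the first single change that can be read, and it gives a number 34.7 percentage points higher from compound 2 to compound 3 (beyond the scatter) with nothing else altered. This position, on an aromatic carbon of a six-membered aromatic ring of carbon only, para to a large group, is therefore not indifferent to what stands on it: chloro in place of hydrogen moves the inhibition at the dose given clearly upward. Nothing available here accounts for the size of this step.

As far as these compounds go, how a methoxy group, an amine or a carboxylic acid on the same carbon would compare with chloro stays open. Also open is whether this change gives a step of similar size on another core, such as that of compound 1, which has no matched partner among the compounds shown.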